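Ethylsulfonyl to propylsulfonyl: working notes on the series

A few compounds are considered here, and "the series" means these few. Any claim that something is new, unique, unknown or untested is made for them only; others in the source may bear on it.

In an ADME assay on RAW264.7 cells (Mus musculus) for cytotoxicity, read by MTT assay, with a stated time of 24 h (a higher number here means a weaker inhibitor, a lower number a stronger inhibitor), compound 1 (`CS(=O)(=O)Oc1ccc2c3c(c(=O)oc2c1)CCCCCC3`) gives 24500 nM, and compound 2 (`CCS(=O)(=O)Oc1ccc2c3c(c(=O)oc2c1)CCCCCC3`) gives 21500 nM. Among the compounds with values here, compound 2 therefore stands within the scatter of compound 1, the only other measured number.

The next compound is compound 3 (`CCCS(=O)(=O)Oc1ccc2c3c(c(=O)oc2c1)CCCCCC3`), which turns ethylsulfonyl into propylsulfonyl: methyl in place of hydrogen on a saturated chain carbon, two bonds along the chain from a sulfonyl sulfur. In words, this is methyl in place of hydrogen on a saturated chain carbon, two bonds along the chain from a sulfonyl sulfur.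

Within the data shown here, one measured step bears on this change. Methyl in place of hydrogen on a saturated chain carbon bound to a sulfonyl sulfur gave a 1.1-fold lower number from compound 1 to compound 2 (0.06 log units; within the scatter). Among the measured compounds shown here, that is a single small step, and the data hold no measured propylsulfonyl compound to test it against. No shift beyond the scatter is expected in this assay, and no direction can be assigned with confidence. The expected size of the change is a 1.1-fold lower number from compound 2 to compound 3 (0.03 log units; within the scatter). For compound 3 the estimated value is 20000 nM, with an expected range of 10000 nM to 38000 nM.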

Compound 3, half-maximal inhibitory concentration: 9200 nM
Compound 3: the middle estimate sits 2.2-fold (0.34 log units) above what was measured; measured number below the stated range.
By their numbers in this assay, from the lowest: compound 3; then compounds 2 and 1 (each within the scatter of the next).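

In this assay, within the data shown here, the position two bonds along the chain from a sulfonyl sulfur is the first place where a single methyl in place of hydrogen moves the number beyond the scatter, giving a 2.3-fold lower number from compound 2 to compound 3 (0.37 log units; beyond the scatter) in the modest range. The same kind of replacement on the chain carbon bound to the sulfonyl sulfur had given only a 1.1-fold lower number from compound 1 to compound 2 (0.06 log units; within the scatter) and so had shown no measurable change. The ethyl replacement on that bound carbon gives a 2.7-fold lower number from compound 1 to compound 3 (0.43 log units; beyond the scatter) and places propylsulfonyl clear of both other compounds, though no evidence at hand explains this separation.

The compounds shown leave open whether a longer chain such as butyl on the sulfonyl sulfur would lower the number further or reverse the step, and whether branched isopropyl would match straight propyl. Among these compounds, they also leave open how the number would respond to an amine or a carboxylic acid at the end of the propyl chain, so the step so far describes plain saturated chains alone.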